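Indole substitution at the aromatic carbon of compound 1's core

The compounds below may be only part of what the source reports. "The series", "measured", "known", "first", "only" and "open" are said of these compounds alone.

Measured compounds:
compound 1 `COC(=O)[C@@]1(C)CCC=C2[C@@H]1CC[C@@H](C)[C@]2(C)Cc1c[nH]c2ccccc12`: 3600 nM
compound 2 `COC(=O)[C@@]1(C)CCC=C2[C@@H]1CC[C@@H](C)[C@]2(C)Cc1c[nH]c2ccc(Br)cc12`: 10000 nM

In a functional assay on HeLa cells (Homo sapiens) for inhibition, read by sulforhodamine B assay, with a stated time of 48 h (on this read-out higher numbers stand for weaker inhibition of growth and lower numbers for stronger inhibition of growth), compound 1 gives the lowest of the two numbers; the nearest is compound 2, at 10000 nM. The step of a 2.8-fold higher number from compound 1 to compound 2 (0.44 log units; beyond the scatter) is modest but beyond the scatter.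

Compound 3 `COC(=O)[C@@]1(C)CCC=C2[C@@H]1CC[C@@H](C)[C@]2(C)Cc1c[nH]c2ccc(C(F)(F)F)cc12` differs from compound 1 by trifluoromethyl in place of hydrogen on an aromatic carbon at the same aromatic carbon where compound 2 carries bromo. Among the compounds with values here, only that one step bears on it, and a weakening of similar size is expected for compound 3, a 2.5-fold higher number from compound 1 to compound 3 (0.40 log units; beyond the scatter), so that compound 3 is estimated at 9000 nM with a range of 4000 nM to 22000 nM.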

Compound 3, concentration for 50% growth inhibition: 11000 nM
Estimate against measurement, compound 3: 1.2-fold (0.09 log units) below; measured number inside the range.
By their numbers in this assay, from the lowest: compound 1; then compounds 2 and 3 (each within the scatter of the next).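

In this assay, a second group at this aromatic carbon also weakens growth inhibition, with a 3.1-fold higher number from compound 1 to compound 3 (0.49 log units; beyond the scatter), so hydrogen gives the lowest number of the three compounds. Trifluoromethyl and bromo cannot be told apart here, with a 1.1-fold higher number from compound 2 to compound 3 (0.04 log units; within the scatter). The data shown offer no explanation for either result.

Open, going by these compounds, is whether an amine, a methoxy group or a carboxylic acid at this carbon would also weaken growth inhibition. Also open, on these data alone, is whether trifluoromethyl or bromo would act the same way elsewhere on the six-membered aromatic ring.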